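A few compounds are considered here, and "the series" means these few. Any claim that something is new, unique, unknown or untested is made for them only; others in the source may bear on it.

In an in vitro ADME assay on microsomes from liver (Rattus norvegicus) for metabolic stability, tested at 5 uM (on this read-out lower numbers stand for a shorter-lived compound and higher numbers for a longer-lived compound), the measured compounds stand as follows:
compound 1 `C=CC(=O)NCc1coc(-c2c(N)ncnc2Nc2ccc(Oc3ccccc3)c(Cl)c2)n1` gives 0.983 h;
compound 2 `C=CC(=O)NCc1coc(-c2c(N)ncnc2Nc2ccc(Oc3cc(Cl)ccc3Cl)c(Cl)c2)n1` gives 0.85 h;
compound 3 `C=CC(=O)NCc1coc(-c2c(N)ncnc2Nc2ccc(Oc3ccccn3)c(Cl)c2)n1` gives 0.267 h.

Compound 2 has the second highest number of the three. Its nearest neighbour is compound 1, and that pair differ by a 1.2-fold lower number from compound 1 to compound 2 (0.06 log units; within the scatter), within the scatter. Its furthest neighbour is compound 3, reached by a 3.2-fold lower number from compound 2 to compound 3 (0.50 log units; beyond the scatter), beyond the scatter.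

Compound 4 `C=CC(=O)NCc1coc(-c2c(N)ncnc2Nc2ccc(Oc3cccnc3)c(Cl)c2)n1` has not yet been measured. It differs from compound 2 by pyridin-3-yl in place of 2,5-dichlorophenyl on an oxygen on an aromatic ring. Within the data shown here, two measured steps bear on this change, both putting a pyridinyl ring on the same oxygen: a 3.2-fold lower number from compound 2 to compound 3 (0.50 log units; beyond the scatter) and a 3.7-fold lower number from compound 1 to compound 3 (0.57 log units; beyond the scatter). Both are modest lowerings in this assay beyond the scatter. The two steps are a guide rather than an exact match: compound 3 carries pyridin-2-yl, whereas compound 4 carries pyridin-3-yl. A lowering of similar size, or somewhat smaller, is expected. Compound 4 is therefore estimated to give about 0.35 h in this assay, within a range of 0.15 h to 0.85 h. The expected step is a 2.4-fold lower number from compound 2 to compound 4 (0.39 log units; beyond the scatter).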

Compound 4, half-life: 0.15 h
Estimate against measurement, compound 4: 2.3-fold (0.37 log units) above, and the stated range covers the measured number.
By their numbers in this assay, from the lowest: compounds 4 and 3 (each within the scatter of the next); then compounds 2 and 1 (each within the scatter of the next).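

In this assay, compound 4 shows that the lowering seen with pyridin-2-yl on this oxygen is not confined to that one group: pyridin-3-yl also gives a 5.7-fold lower number from compound 2 to compound 4 (0.75 log units; beyond the scatter) and a 6.6-fold lower number from compound 1 to compound 4 (0.82 log units; beyond the scatter). The two pyridinyl groups are not told apart here, since a 1.8-fold lower number from compound 3 to compound 4 (0.25 log units; within the scatter) stays within the scatter. Across these four compounds, the two groups with a ring nitrogen therefore stand together at the low end and phenyl and 2,5-dichlorophenyl stand together at the high end, with no compound going against that split.

From the compounds shown here alone, whether a pyridin-4-yl group, a pyrimidinyl ring or a phenyl ring carrying an amine would fall with the low pair or the high pair remains open. Nothing given here offers a measured explanation for the split between these groups.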